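Swapping the aryl group on the pyrazole of a urea TRPV1 antagonist

The compounds below may be only part of what the source reports. "The series", "measured", "known", "first", "only" and "open" are said of these compounds alone.

Measured compounds:
Compound 1, `O=C(NCc1cc(C(F)(F)F)nn1-c1cccc(C(F)(F)F)c1)Nc1cccc2[nH]ncc12`, in an assay on CHO-K1 cells for antagonist activity at transient receptor potential cation channel subfamily V member 1 (Homo sapiens), read by FLIPR and calcium flux, with a stated time of 6 min (a lower number here means a stronger inhibitor, a higher number a weaker inhibitor), gives 1.3 nM.
Compound 2, `O=C(NCc1cc(C(F)(F)F)nn1-c1ccc(C(F)(F)F)cc1)Nc1cccc2[nH]ncc12`, in this assay gives 3.8 nM.
Compound 3, `CC(C)(C)c1cc(CNC(=O)Nc2cccc3[nH]ncc23)n(-c2cccc(C(F)(F)F)c2)n1`, in this assay gives 0.3 nM.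

Compound 3 gives the lowest number of the three in this assay; compound 1 is nearest to it, and compound 2 furthest, both steps beyond the scatter.

Compound 4, `CC(C)(C)c1cc(CNC(=O)Nc2cccc3[nH]ncc23)n(-c2ccc(F)c(F)c2)n1`, has not yet been measured. It differs from compound 3 in one place: 3,4-difluorophenyl in place of 3-(trifluoromethyl)phenyl on an aromatic nitrogen.

For the measured compounds named here, no measured step makes exactly this change. Going by the values given here, two steps bear on it indirectly. Moving the trifluoromethyl group around the phenyl ring gave a 2.9-fold higher number from compound 1 to compound 2 (0.47 log units; beyond the scatter), showing that the aryl group on the ring nitrogen matters. Changing the group on the ring carbon gave a 4.3-fold lower number from compound 1 to compound 3 (0.64 log units; beyond the scatter), which is the change compound 4 keeps. Since the aryl group is altered in a way not yet tested, a modest weakening is expected rather than none: a 2.7-fold higher number from compound 3 to compound 4 (0.43 log units; beyond the scatter) is the estimated step in this assay.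

Compound 4 is therefore expected to give about 0.8 nM in this assay, within roughly 0.3 nM to 3 nM.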

Compound 4, inhibition constant: 0.5 nM
Beside the measured number, compound 4's estimate is 1.6-fold (0.20 log units) above it; measured number inside the range.
By their numbers in this assay, from the lowest: compounds 3 and 4 (each within the scatter of the next); then compound 1; then compound 2.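

Replacing 3-(trifluoromethyl)phenyl with 3,4-difluorophenyl on the aromatic nitrogen gives a 1.7-fold higher number from compound 3 to compound 4 (0.22 log units; within the scatter) in this assay, so the two aryl groups cannot be told apart in this assay. The earlier change at this position, a 2.9-fold higher number from compound 1 to compound 2 (0.47 log units; beyond the scatter), moved the trifluoromethyl group and lay beyond the scatter, whereas this result shows that, with tert-butyl kept on the pyrazole, a quite different fluorine pattern on the phenyl ring can be accepted without a measurable loss. Nothing available explains why these two aryl groups read alike.

From the compounds shown here alone, it remains open whether this tolerance extends to a phenyl ring carrying an amine or a carboxylic acid rather than fluorine-containing groups. Going by these compounds, it is equally open whether 3,4-difluorophenyl would behave the same way with trifluoromethyl in place of the tert-butyl group.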